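Bromo to methyl on the aryl ring of a thiazolylidene hydrazide

The compounds below may be only part of what the source reports. "The series", "measured", "known", "first", "only" and "open" are said of these compounds alone.

Compound 2 `O=C(CSc1ncccn1)N/N=c1/scc(-c2ccc(Br)cc2)n1-c1ccccc1`: 69%
Compound 1 `Cc1ccc(-c2cs/c(=N/NC(=O)CSc3nnnn3C)n2-c2ccccc2)cc1`: 44.3%

In a functional assay on C6 cells (Rattus norvegicus) for cytotoxicity, read by MTT assay, with a stated time of 24 h, tested at 50 ug/mL (a higher number here means a weaker effect of the compound at the concentration tested, a lower number a stronger effect), compound 2 gives the higher of the two numbers; compound 1 gives 44.3%, a number lower by more than the usual scatter. Compound 3 `Cc1ccc(-c2cs/c(=N/NC(=O)CSc3ncccn3)n2-c2ccccc2)cc1` is not yet measured. It differs from compound 2 by methyl in place of bromo on an aromatic carbon. For the measured compounds named here, no measured pair shows this change alone, so the expected size of the step in this assay is uncertain; a modest move downward, toward the number of compound 1, is expected, since compound 1 also carries the methyl and gives 44.3%. Compound 3 is expected to give about 57%, in a range from 38% to 76%.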

Compound 3, a percentage reported as activity, at one concentration (the size of the read-out at that concentration, not a potency): 64.4%
Estimate against measurement, compound 3: 7.4 percentage points below; low and high end bracket the measured number.
By their numbers in this assay, from the lowest: compound 1; then compounds 3 and 2 (each within the scatter of the next).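

In this assay, methyl in place of bromo gives a number 4.6 percentage points lower from compound 2 to compound 3 (within the scatter) and so, on this aromatic carbon, the two groups cannot be told apart. For the compounds shown here, the change on the sulfur, pyrimidin-2-yl in place of 1-methyl-1H-tetrazol-5-yl, gives a number 20.1 percentage points higher from compound 1 to compound 3 (beyond the scatter) and is the only single change here that reaches beyond the scatter. Nothing at hand explains either step. Still open, as far as these compounds go, is how a quite different group at this position, such as an amine or a carboxylic acid, would read. Also open, from the compounds shown here alone, is whether bromo and methyl would match with the 1-methyl-1H-tetrazol-5-yl group on the sulfur.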